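The source may report more compounds than this note shows. Statements on the series, on what has been measured and on what is new or still open speak of the compounds shown alone.

Measured so far:
- compound 1 `O=C(Nc1cccc(-n2cc(-c3ccncc3)c(-c3cc(O)cc(Cl)c3)n2)c1)Nc1ccc(Cl)c(C(F)(F)F)c1`; in a functional assay on SK-MEL-28 cells (Homo sapiens) for inhibition, read by sulforhodamine B assay, with a stated time of 48 h, tested at 100 uM (on this read-out lower numbers stand for a stronger effect and higher numbers for a weaker effect at the one concentration tested), compound 1 gives -89%.
- compound 2 `O=C(Nc1cccc(-n2cc(-c3ccncc3)c(-c3cc(O)cc(Cl)c3)n2)c1)Nc1ccc(Cl)c(Cl)c1`; in this assay compound 2 gives -52%.

Compound 1 stands lowest of the two numbers. Its nearest neighbour is compound 2, and the gap is the step of a number 37 percentage points higher from compound 1 to compound 2 (beyond the scatter), which comes from chloro in place of trifluoromethyl on an aromatic carbon.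

Compound 3 `COc1cc(Cl)cc(-c2nn(-c3cccc(NC(=O)Nc4ccc(Cl)c(C(F)(F)F)c4)c3)cc2-c2ccncc2)c1` has not yet been measured. It differs from compound 1 by methyl in place of hydrogen on an oxygen on an aromatic ring; cut one bond further out, this reads hydroxy to methoxy, 3-chloro-5-hydroxyphenyl to 3-chloro-5-methoxyphenyl.

Among the compounds with values here, no measured step touches this oxygen. Within the data shown here, the only step in hand, a number 37 percentage points higher from compound 1 to compound 2 (beyond the scatter), alters a different part of the shared core and shows only that a single change can move this assay well beyond the scatter. The series holds no hydroxy-to-methoxy comparison, so the direction for compound 3 is open, with a shift toward a higher number held possible. The step expected from compound 1 to compound 3 is a number 24 percentage points higher from compound 1 to compound 3 (beyond the scatter). Compound 3 is estimated at -65%, in a range from -95% to -20%.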

Compound 3, a percentage reported as activity, at one concentration (the size of the read-out at that concentration, not a potency): -88%
The estimate for compound 3 lay 23 percentage points above the measured number; low and high end bracket the measured number.
By their numbers in this assay, from the lowest: compounds 1 and 3 (each within the scatter of the next); then compound 2.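

In this assay, methyl in place of hydrogen on the oxygen gives a number 1 percentage points higher from compound 1 to compound 3 (within the scatter), so compound 1 and compound 3 cannot be told apart on this read-out. Within the data shown here, for this pair, then, the hydrogen of the hydroxy group is not required for the effect seen at the one concentration tested, and methoxy serves as well as hydroxy in the 3-chloro-5-substituted phenyl group, whereas the only earlier step, a number 37 percentage points higher from compound 1 to compound 2 (beyond the scatter), showed sensitivity at a different place on the shared core. Nothing at hand explains why this change leaves the read-out level.

Still open, as far as these compounds go, is whether this tolerance extends beyond a single methyl: an ethoxy group, a longer chain on the oxygen, or an amine or carboxylic acid in place of the hydroxy group could each give a different result. Also open, from the compounds shown here alone, are whether methoxy would behave the same way alongside the chloro of compound 2, and whether compound 1 and compound 3 would still give an effect of the same size at other concentrations.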